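A Methoxy Group Replaces a Nitro Group on a Shared Core

A few compounds are considered here, and "the series" means these few. Any claim that something is new, unique, unknown or untested is made for them only; others in the source may bear on it.

Compound 3 `O=C(O)c1ccc(C(=O)/C(=C\c2ccc(F)cc2[N+](=O)[O-])SCc2ccc(Br)cc2)cc1` is reported in a physicochemical assay for solubility (a higher number here means a more soluble compound, a lower number a less soluble compound), only as a limit, at < 1000 ug/mL. Compound 1 `O=C(/C(=C\c1ccc(F)c([N+](=O)[O-])c1)SCc1ccc(F)cc1)c1ccc(F)cc1` likewise reaches only a limit in this assay, < 1000 ug/mL. Compound 2 `O=C(O)c1ccc(C(=O)/C(=C\c2ccc(Br)c([N+](=O)[O-])c2)SCc2ccc(Br)cc2)cc1` also stops at a limit, < 1000 ug/mL. Because every value sits at the limit of < 1000 ug/mL in this assay, at which 3 of the 3 values shown sit, the step that the two limits leave unreadable from compound 2 to compound 3 cannot be read in size or direction. Compound 4 `COc1cc(/C=C(/SCc2ccc(Br)cc2)C(=O)c2ccc(C(=O)O)cc2)ccc1F` differs from compound 3 in one place: 4-fluoro-3-methoxyphenyl in place of 4-fluoro-2-nitrophenyl on a double-bonded chain carbon bound to a double-bonded chain carbon. Within the data shown here, no measured step bears on this change, and the one step that exists among the measured compounds was itself unreadable, so no direction can be drawn from the data. Compound 4 is therefore expected to stay near the same limit, with an estimated step that the limit leaves unreadable from compound 3 to compound 4 and an estimated value of 300 ug/mL, between 40 ug/mL and 950 ug/mL.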

Compound 4, solubility: < 1000 ug/mL
Compound 4: a limit, no number; the forecaster's own chance of this, stated with the estimate: 80%; the middle value is on the limit's open side.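

Compound 4 also gives only a limit in this assay, so its steps from compound 2 and compound 3 cannot be read: the limit of < 1000 ug/mL in this assay, at which 4 of the 4 values shown sit.

The compounds shown leave open how 4-fluoro-3-methoxyphenyl and 4-fluoro-2-nitrophenyl compare in this assay, since none has an actual number.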